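Adding a Methoxy Group: From Compound 2 to Compound 3

The source may report more compounds than this note shows. Statements on the series, on what has been measured and on what is new or still open speak of the compounds shown alone.

Measured so far:
- compound 1 `COc1cc(-c2cc(/C=C/C(=O)c3ccc(N)cc3)[nH]n2)cc(OC)c1OC`: in a functional assay on MOLT-4 cells (Homo sapiens) for cytotoxicity, read by sulforhodamine B assay, with a stated time of 48 h, tested at 0.1 uM (a higher number here means a weaker effect of the compound at the concentration tested, a lower number a stronger effect), compound 1 gives 102%
- compound 2 `COc1ccc(C(=O)/C=C/c2cc(-c3cc(OC)c(OC)c(OC)c3)n[nH]2)cc1OC`: in this assay compound 2 gives 98%

Compound 2 stands at one end of the two numbers shown, yet a number 4 percentage points lower from compound 1 to compound 2 (within the scatter) lies within the scatter, so the two compounds cannot be told apart. Compound 3 `COc1cc(C(=O)/C=C/c2cc(-c3cc(OC)c(OC)c(OC)c3)n[nH]2)cc(OC)c1OC` differs from compound 2 by methoxy in place of hydrogen on an aromatic carbon. Among the compounds with values here, no measured step involves adding a methoxy group, and the single step seen is within the scatter. For compound 3 no step beyond the scatter is expected: a number 1 percentage points lower from compound 2 to compound 3 (within the scatter). Compound 3 is therefore expected to give 97%, with a range from 84% to 110%.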

Compound 3, a percentage reported as activity, at one concentration (the size of the read-out at that concentration, not a potency): 112%
Estimate against measurement, compound 3: 15 percentage points below; measured number above the stated range.
By their numbers in this assay, from the lowest: compounds 2, 1 and 3 (each within the scatter of the next, the first and the last beyond it).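

In this assay, methoxy in place of hydrogen on an aromatic carbon, ortho to a methoxy group, gives a number 14 percentage points higher from compound 2 to compound 3 (beyond the scatter), so this position is not indifferent to change: the added group goes with a weaker effect at the concentration tested. This is the only step shown that lies beyond the scatter. No measurement offers an explanation for it.

From the compounds shown here alone, whether a hydroxy group, a chlorine atom or an amine at this place would shift the number in the same way remains open.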